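This account rests on a few compounds, and the source may have more. Where it says the series, first, only, none or still open, it means among the compounds named here.

Values measured in a physicochemical assay for solubility, read by HPLC, in phosphate buffer, measured as kinetic solubility, at pH 7.4; on this read-out lower numbers stand for lower solubility and higher numbers for higher solubility:
- compound 1 `CCOC(=O)c1cc(-c2ccc(Cl)cc2)n(-c2ccc(S(N)(=O)=O)cc2)c1C` gives 4200 nM
- compound 2 `CCOC(=O)c1cc(-c2ccc(Cl)cc2)n(-c2ccc(S(N)(=O)=O)cc2)c1` gives 10800 nM
- compound 3 `CCOC(=O)c1cc(-c2ccc(F)cc2)n(-c2ccc(S(N)(=O)=O)cc2)c1` gives 36400 nM

Compound 2 stands second highest of these three numbers, with compound 1 lower and compound 3 higher, both beyond the scatter. Compound 4 `CCOC(=O)c1cc(-c2ccc(Cl)cc2)n(-c2ccc(S(N)(=O)=O)cc2)c1N` has amino in place of hydrogen on an aromatic carbon of compound 2 : amino in place of hydrogen on an aromatic carbon. The most relevant measured change is at that same carbon, where hydrogen replaces methyl: a 2.6-fold higher number from compound 1 to compound 2 (0.41 log units; beyond the scatter). Read in reverse, that modest step shows a lower number when the carbon carries a group. The other measured step, a 3.4-fold higher number from compound 2 to compound 3 (0.53 log units; beyond the scatter), is also modest but concerns fluoro in place of chloro, so it bears on the size of steps in this series and not on the direction here. Going by the values given here, no measured compound carries amino, so the comparison with methyl remains uncertain. A modest move to a lower number is expected, and the estimated change is a 2.2-fold lower number from compound 2 to compound 4 (0.33 log units; beyond the scatter). For compound 4 the estimated value is 5000 nM, with an expected range of 1800 nM to 14000 nM.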

Compound 4, solubility: 4400 nM
Beside the measured number, compound 4's estimate is 1.1-fold (0.06 log units) above it; low and high end bracket the measured number.
By their numbers in this assay, from the lowest: compounds 1 and 4 (each within the scatter of the next); then compound 2; then compound 3.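

In this assay, a second group at the aromatic carbon next to the ring nitrogen now gives a step from hydrogen, with amino giving a 2.5-fold lower number from compound 2 to compound 4 (0.39 log units; beyond the scatter). Amino and methyl at this carbon cannot be told apart, with a 1.0-fold higher number from compound 1 to compound 4 (0.02 log units; within the scatter), so in this pair a hydrogen-bond donor in the entering group brings no separation from methyl. No measurement shown accounts for the step at this carbon.

Going by these compounds, whether other groups at this carbon, such as a hydroxyl, a carboxylic acid or a longer chain, would fall level with amino and methyl stays open. Also open, on these data alone, is whether the amino step holds with fluoro in place of chloro, as in compound 3.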